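Cytotoxicity notes on the bromonaphthyl thiazole series

The compounds below may be only part of what the source reports. "The series", "measured", "known", "first", "only" and "open" are said of these compounds alone.

Three members of the series have been run in an ADME assay on HepG2 2.2.15 cells (Homo sapiens) for cytotoxicity; on this read-out lower numbers stand for higher toxicity in this test and higher numbers for lower toxicity in this test. Compound 1 `O=C(Nc1ncc(Cc2ccc(Br)cc2)s1)c1ccc2ccccc2c1` carries the simpler amide framework, and in this assay compound 1 gives > 50000 nM, which is a limit of the assay rather than a number. Compound 2 `CCCCC(CC)CNc1ncc(C(Oc2ccc3cc(Br)ccc3c2)c2ccc(Cl)cc2)s1` is recorded in this assay as "not toxic" (no number reported), without a number. Compound 3 `Clc1ccc(C(Oc2ccc3cc(Br)ccc3c2)c2cnc(NCC3CCCCC3)s2)cc1` likewise stands in this assay at "not toxic" (no number reported), so no single value is available for it. Of the three entries, one is a limit and two more have no number. For compound 1, the limit of > 50000 nM in this assay, at which 1 of the 3 values shown sits, marks where its reading falls.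

Compound 4 `COCCCNc1ncc(C(Oc2ccc3cc(Br)ccc3c2)c2ccc(Cl)cc2)s1` differs from compound 3 only by 2-methoxyethyl in place of cyclohexyl on a saturated chain carbon bound to a nitrogen on an aromatic ring. Among the compounds with values here, with no measured step to lean on, no shift beyond the scatter is expected in this assay. Compound 4 is expected to read about 80000 nM in this assay, with a range of 30000 nM to 200000 nM, most likely reported again as a limit.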

Compound 4, half-maximal cytotoxic concentration: "not toxic" (no number reported)
No number was reported for compound 4, so the estimate cannot be set against anything.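

Compound 3 and compound 4 are both recorded as "not toxic" in this assay with no number, so no step can be read between them. Left open is whether 2-methoxyethyl in place of cyclohexyl shifts this read-out at all, and compound 1 offers only a limit: the limit of > 50000 nM in this assay, at which 1 of the 4 values shown sits.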